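Acyl change from chloromethyl to bromopropenyl in the series

This account rests on a few compounds, and the source may have more. Where it says the series, first, only, none or still open, it means among the compounds named here.

Measured so far in a functional assay on KYSE-450 cells (Homo sapiens) for inhibition, read by MTT assay, with a stated time of 48 h; on this read-out higher numbers stand for weaker inhibition and lower numbers for stronger inhibition
- compound 1 `C/C=C/C=C/C(=O)N(Cc1ccc(OC)c(O)c1)c1cc(OC)c(OC)c(OC)c1` gives 180 nM
- compound 2 `COc1ccc(CN(C(=O)CO)c2cc(OC)c(OC)c(OC)c2)cc1O` gives 370 nM
- compound 3 `COc1ccc(CN(C(=O)CCl)c2cc(OC)c(OC)c(OC)c2)cc1O` gives 210 nM

Compound 3 at 210 nM cannot be separated from either of the other two compounds. The measured steps are a 1.2-fold higher number from compound 1 to compound 3 (0.07 log units; within the scatter) and a 1.8-fold lower number from compound 2 to compound 3 (0.25 log units; within the scatter). Going by the values given here, only one measured step passes the scatter, and it is modest: a 2.1-fold higher number from compound 1 to compound 2 (0.31 log units; beyond the scatter).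

The next compound is compound 4 `COc1ccc(CN(C(=O)/C=C/CBr)c2cc(OC)c(OC)c(OC)c2)cc1O`. The change is 3-bromoprop-1-en-1-yl in place of chloromethyl on a carbonyl carbon.

All three measured steps bear on this change, since each alters the group on the same carbonyl carbon. Across penta-1,3-dien-1-yl, hydroxymethyl and chloromethyl at that place, the values stay close, and no compound in this small set goes against that. Among the compounds with values here, the closest precedent for a chain with a double bond is compound 1 at 180 nM. Within the data shown here, no measured compound carries bromine, so the data cannot speak to that atom directly, and the range is kept wide.

A step no larger than the modest one already seen is therefore expected, most likely none beyond the scatter. The estimated step in this assay is a 1.2-fold lower number from compound 3 to compound 4 (0.09 log units; within the scatter). Compound 4 is estimated at 170 nM, with an expected range of 60 nM to 450 nM.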

Compound 4, half-maximal inhibitory concentration: 100 nM
Compound 4: the middle estimate sits 1.7-fold (0.23 log units) above what was measured; the measured number falls inside the stated range.
By their numbers in this assay, from the lowest: compounds 4, 1, 3 and 2 (each within the scatter of the next, the first and the last beyond it).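

In (this assay), 3-bromoprop-1-en-1-yl in place of chloromethyl on the carbonyl carbon gives a step beyond the scatter (a 2.1-fold lower number from compound 3 to compound 4 (0.32 log units; beyond the scatter)), whereas chloromethyl could not be separated from either of the other two groups. Against hydroxymethyl, the same group gives the largest step in the set so far, though it is still modest (a 3.7-fold lower number from compound 2 to compound 4 (0.57 log units; beyond the scatter)), so the group at this place can shift the number beyond the scatter. Against penta-1,3-dien-1-yl the step stays within the scatter (a 1.8-fold lower number from compound 1 to compound 4 (0.26 log units; within the scatter)), so the two chains with a double bond are not separated, and no measurement at hand accounts for the step from chloromethyl.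

The compounds shown do not divide the step among bromine, the double bond and the longer chain; a bromomethyl group and an unbrominated prop-1-en-1-yl group on the same carbonyl carbon would begin to separate them. Also open, on these data alone, is how this place responds to an amine or a carboxylic acid at the end of such a chain.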